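A few compounds are considered here, and "the series" means these few. Any claim that something is new, unique, unknown or untested is made for them only; others in the source may bear on it.

Compound 1, whose structure is `CCCCNc1nc(N)nc2ccn(Cc3ccccn3)c12`, is the starting point of this small set. In an ADME assay on HEK293 cells (Homo sapiens) for cytotoxicity, read by ATP content, with a stated time of 6 h (a higher number here means that more compound is tolerated, a lower number that less compound is tolerated), compound 1 gives > 24000 nM, which is a limit of the assay rather than a number. Compound 2 `CCCCNc1nc(N)nc2ccn(Cc3cccc(C)n3)c12` differs from compound 1 in the way counted as methyl in place of hydrogen on an aromatic carbon. In this assay compound 2 gives > 24000 nM, again a limit. The step that the two limits leave unreadable from compound 1 to compound 2 therefore cannot be sized. Compound 3 `Nc1nc(NCc2nccs2)c2c(ccn2Cc2ccccn2)n1` differs from compound 1 by 1,3-thiazol-2-yl in place of propyl on a saturated chain carbon bound to a nitrogen on an aromatic ring, and this is also how the core of compound 3 differs from the core of compound 1. In this assay compound 3 gives > 24000 nM, a limit. The step that the two limits leave unreadable from compound 1 to compound 3 is likewise unreadable. What the set shows is the limit of > 24000 nM in this assay, at which 3 of the 3 values shown sit.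

Compound 4 `Cc1cnc(CNc2nc(N)nc3ccn(Cc4ccccn4)c23)s1` is not yet measured. It differs from compound 3 by methyl in place of hydrogen on an aromatic carbon. Within the data shown here, this is the same kind of change as the one from compound 1 to compound 2, but the surroundings differ: in compound 2 the methyl sits on a six-membered aromatic ring with 1 nitrogen, next to the ring nitrogen and meta to a large group, whereas in compound 4 it sits on a five-membered aromatic ring with 1 nitrogen and 1 sulfur, next to the ring sulfur, two ring bonds from the ring nitrogen and two ring bonds from the ring atom that bears a large group. Among the measured compounds shown here, the expected step that the limit leaves unreadable from compound 3 to compound 4 is set beside the unreadable a step that the two limits leave unreadable from compound 1 to compound 2 and rests on (the limit of > 24000 nM in this assay, at which 3 of the 3 values shown sit), since every value so far is a limit. Compound 4 is estimated at 30000 nM, with a range from 12000 nM to 80000 nM, and most likely the assay will again report only a limit.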

Compound 4, half-maximal cytotoxic concentration: > 24000 nM
Compound 4: no number, only a limit (the forecaster's own chance of this, stated with the estimate: 80%); the middle value does not contradict the limit.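

In this assay compound 4 gives > 24000 nM, again a limit of the assay and not a number, and no new step can be read between compound 4 and either compound 3 or compound 1. The compounds shown leave open whether any of these changes alters the concentration tolerated in this assay, because no reading is a number: the limit of > 24000 nM in this assay, at which 4 of the 4 values shown sit.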